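The source may hold more compounds than are shown below. What is called first, only, known or untested is meant among the compounds shown, and "the series" means these compounds.

Measured so far:
Compound 1, `O=C(O)Cc1ccc(C=C2CCN(C(=O)C(C3CCCCC3)C3CCCCC3)CC2)c(F)c1`: in an assay on Prostate gland for inhibition of 3-oxo-5-alpha-steroid 4-dehydrogenase 1 (Rattus norvegicus) (a higher number here means a weaker inhibitor, a lower number a stronger inhibitor), compound 1 gives 3200 nM.
Compound 2, `O=C(O)Cc1ccc(C=C2CCN(C(=O)C(c3ccccc3)c3ccccc3)CC2)cc1`: in this assay compound 2 gives 4500 nM.

Of these two numbers, compound 2 has the higher one, but its gap to compound 1 lies within the usual scatter of repeated measurements, so the two cannot be ranked against each other. Compound 3, `O=C(O)c1ccc(C=C2CCN(C(=O)C(c3ccccc3)c3ccccc3)CC2)cc1`, has not yet been tested in this assay. It differs from compound 2 in one place: carboxy in place of carboxymethyl on an aromatic carbon. Cut one bond further out, the same difference reads 4-(carboxymethyl)phenyl to 4-carboxyphenyl; everything else in the molecule stays as in compound 2. Within the data shown here, no measured pair shows what such a shortening does in this assay, so there is no step to lean on. A change of this kind could move the number either way; a step of moderate size, somewhat more likely toward a higher number than a lower one, seems plausible, though a step within the scatter cannot be excluded. Compound 3 is therefore expected to give about 6500 nM, within roughly 2000 nM to 20000 nM. That expectation corresponds to a step of a 1.4-fold higher number from compound 2 to compound 3 (0.16 log units; within the scatter).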

Compound 3, half-maximal inhibitory concentration: 3400 nM
For compound 3 the middle estimate is 1.9-fold (0.28 log units) above the measured one; the measured number falls inside the stated range.
By their numbers in this assay, from the lowest: compounds 1, 3 and 2 (each within the scatter of the next).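

Swapping carboxymethyl for carboxy on the aromatic carbon para to a large group gives (a 1.3-fold lower number from compound 2 to compound 3 (0.12 log units; within the scatter)) in this assay and so leaves the reading within the noise of the measurement. This first matched pair shows that, with the rest of compound 2 held fixed, the two groups cannot be told apart in this test, so the length of the link between the ring and the acid makes no measurable difference across this one change. No separate measurement bears on why the two groups read alike.

Still open, going by these compounds, is whether this tolerance extends to a longer chain ending in a carboxylic acid, or to a group with no acid at all, such as an amine or a nitrile, at the same position. Compound 1 differs from compound 2 and compound 3 in more than one place, so it cannot show whether the same swap would behave alike on a different core.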